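Ester chain trimming in a thiophene-bearing dihydropyrimidine series

A few compounds are considered here, and "the series" means these few. Any claim that something is new, unique, unknown or untested is made for them only; others in the source may bear on it.

Measured compounds:
- compound 1 `CCCOC(=O)C1=C(C)NC(=S)NC1c1ccsc1`: 26%
- compound 2 `CC1=C(C(=O)OCC(C)C)C(c2ccsc2)NC(=S)N1`: 15%
- compound 3 `CCC(CC)OC(=O)C1=C(C)NC(=O)NC1c1ccsc1`: 26%

All three were tested in an assay on membranes from HEK293 cells for displacement of a labelled ligand from adenosine receptor A2b (Homo sapiens), read by scintillation counting, with a stated time of 30 min, tested at 1 uM; on this read-out lower numbers stand for less inhibition and higher numbers for more inhibition at the one concentration tested (going by the name of the read-out). Compound 2 to compound 1 is a single change, (hydrogen in place of methyl on a saturated chain carbon bound to two saturated chain carbons), and it gave a number 11 percentage points higher from compound 2 to compound 1 (beyond the scatter). Compound 3 carries a different core from compound 2; the difference between the two cores is not broken down here. Compound 3 and compound 1 sit level within the scatter, and both are clear of compound 2.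

Compound 4 `CCC(C)OC(=O)C1=C(C)NC(=O)NC1c1ccsc1` is not yet measured. It differs from compound 3 by hydrogen in place of methyl on a saturated chain carbon, two bonds along the chain from an oxygen next to a carbonyl group. For the measured compounds named here, this is the same kind of change as the one from compound 2 to compound 1, but not the same: there the carbon was bound to two saturated chain carbons, here it is two bonds along the chain from an oxygen next to a carbonyl group. Because the earlier step was a number 11 percentage points higher from compound 2 to compound 1 (beyond the scatter), a step of similar direction is expected for compound 4 in this assay, though it may stay within scatter given the different surroundings. The estimated step is a number 6 percentage points higher from compound 3 to compound 4 (within the scatter). For compound 4 the expected value in this assay is 32%, between 17% and 47%.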

Compound 4, a percentage reported as inhibition, at one concentration (the size of the read-out at that concentration, not a potency): 39%
Compound 4: the middle estimate sits 7 percentage points below what was measured, within the range that was stated.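

In this assay, hydrogen in place of methyl, taking pentan-3-yl to sec-butyl on the ester, gives a number 13 percentage points higher from compound 3 to compound 4 (beyond the scatter). Set beside the earlier step, the trim carries across the two cores in the same direction, with no difference in size that can be told apart: the same change on two cores in this assay, a number 11 percentage points higher (beyond the scatter) from compound 2 to compound 1 and a number 13 percentage points higher (beyond the scatter) from compound 3 to compound 4, 2 percentage points apart, within the scatter of two such steps This rests on only two pairs, in which the methyl leaves from different surroundings on the chain, and on percentages at one concentration, so it shows neither that the step would hold on any further core nor what it does to potency.

Still open, on these data alone, is whether further trimming continues the same trend, or whether a longer chain on the ester reverses it. Also open, as far as these compounds go, is how this assay would read an ester chain carrying an amine or a carboxylic acid, and whether such groups would follow the same step on both cores.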